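Adding a methyl to the butyrate chain of compound 3

The source may report more compounds than this note shows. Statements on the series, on what has been measured and on what is new or still open speak of the compounds shown alone.

compound 1 `COc1cc(/C=C/COC(C)=O)ccc1OC(C)=O` gives 1060 nM
compound 2 `CCCC(=O)OC/C=C/c1ccc(OC(=O)CCC)c(OC)c1` gives 17300 nM
compound 3 `CCCC(=O)OC/C=C/c1ccc(OC(C)=O)c(OC)c1` gives 18500 nM

In a functional assay on U-87MG ATCC cells for antiproliferative activity against U-87 MG (Homo sapiens), read by sulforhodamine B assay, with a stated time of 72 h (a higher number here means a weaker inhibitor, a lower number a stronger inhibitor), compound 3 gives 18500 nM, level with compound 2 and far from compound 1. Compound 4 `CC[C@H](C)C(=O)OC/C=C/c1ccc(OC(C)=O)c(OC)c1` differs from compound 3 by one change: methyl in place of hydrogen on a saturated chain carbon bound to a carbonyl carbon and a saturated chain carbon. Cut one bond further out, this reads propyl to sec-butyl.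

Within the data shown here, two measured steps bear on it. Ethyl in place of hydrogen on a saturated chain carbon bound to a carbonyl carbon gave a 17-fold higher number from compound 1 to compound 3 (1.24 log units; beyond the scatter), a large step on the chain that changes here. Hydrogen in place of ethyl on such a carbon gave a 1.1-fold higher number from compound 2 to compound 3 (0.03 log units; within the scatter), but that step leaves this chain untouched. A single step on this chain is a thin basis, so the range stays wide. No step beyond the scatter is firmly expected in this assay, and any shift is expected towards a higher number. The expected step is a 1.2-fold higher number from compound 3 to compound 4 (0.08 log units; within the scatter). Compound 4 is estimated at 22000 nM, with an expected range of 8000 nM to 60000 nM.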

Compound 4, half-maximal inhibitory concentration: 15000 nM
The estimate for compound 4 lay 1.5-fold (0.17 log units) above the measured number, within the range that was stated.
By their numbers in this assay, from the lowest: compound 1; then compounds 4, 2 and 3 (each within the scatter of the next).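

In this assay, methyl in place of hydrogen on a saturated chain carbon bound to a carbonyl carbon and a saturated chain carbon gives a 1.2-fold lower number from compound 3 to compound 4 (0.09 log units; within the scatter), so turning propyl into sec-butyl leaves this position unchanged within the scatter. The large step away from methyl on this carbonyl carbon also holds for sec-butyl, which gives a 14-fold higher number from compound 1 to compound 4 (1.15 log units; beyond the scatter), in line with the large step already seen for propyl, a 17-fold higher number from compound 1 to compound 3 (1.24 log units; beyond the scatter). No measurement here bears on the reason for either result.

Open, going by these compounds, is where between methyl and propyl on this carbonyl carbon the large step arises, which an ethyl group would help to place. Also open, on these data alone, is how the mirror-image sec-butyl, a tert-butyl group or a longer chain would compare with compound 4.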